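The source may hold more compounds than are shown below. What is called first, only, known or untested is meant among the compounds shown, and "the series" means these compounds.

In a physicochemical assay for solubility, with a stated time of 24 h, at pH 6.8 (on this read-out lower numbers stand for lower solubility and higher numbers for higher solubility), compound 3 `CN(C)C(=O)c1cn(C)c2ccccc12` gives > 51 ug/mL, which is a limit and not a number. Compound 1 `CN(C)C(=O)c1c[nH]c2ccccc12` gives > 44 ug/mL, which is also a limit. Going by the values given here, the only measured step is a step that the two limits leave unreadable from compound 1 to compound 3, and it is methyl in place of hydrogen on an aromatic nitrogen, so it offers no size to carry forward.

Compound 4 `COC(=O)c1ccc2c(C(=O)N(C)C)cn(C)c2c1` differs from compound 3 by methoxycarbonyl in place of hydrogen on an aromatic carbon. Among the compounds with values here, no measured step covers this change. Within the data shown here, compound 2 `COC(=O)c1ccc2c(C(=O)Nc3ccccc3)cn(C)c2c1`, the only measured compound bearing methoxycarbonyl, gives < 1 ug/mL, which is a limit, and the expectation of a fall rests on this one compound. The expected move in this assay is therefore downward, estimated as an at least 2.0-fold lower number from compound 3 to compound 4 (0.30 log units; that floor lies within the scatter), although the limit on compound 3 leaves its size loose. For compound 4 the estimated value is 25 ug/mL, with an expected range of 5 ug/mL to 65 ug/mL.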

Compound 4, solubility: 49 ug/mL
Beside the measured number, compound 4's estimate is 2.0-fold (0.29 log units) below it; the range from low to high includes it.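

In this assay, the change to methoxycarbonyl in place of hydrogen on an aromatic carbon now has a measured number on one side, yet it reads only as an at least 1.0-fold lower number from compound 3 to compound 4 (0.01 log units; that floor lies within the scatter), so no fall beyond the scatter is shown at this place. Compound 2 gives < 1 ug/mL, which is a limit. With methoxycarbonyl held in place, dimethylamino in place of anilino on a carbonyl carbon gives an at least 49-fold higher number from compound 2 to compound 4 (1.69 log units; beyond the scatter), so among the compounds shown the wide gap goes with the group on the carbonyl and not with methoxycarbonyl.

Compound 1 and compound 3 both stand as limits, so the steps that start from them cannot be sized. As far as these compounds go, whether a carboxylic acid or an amine on the same aromatic carbon would give a number like that of compound 4 remains open.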